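A few compounds are considered here, and "the series" means these few. Any claim that something is new, unique, unknown or untested is made for them only; others in the source may bear on it.

Of the compounds shown here, three sharing one core have been measured. Compound 1 `CC(=O)Nc1nc2ccc(NC(=O)c3cc(Br)c(Br)[nH]3)cc2s1` gives only the limit > 50000 nM in a functional assay on SK-BR-3 cells (Homo sapiens) for antiproliferative activity (a lower number here means that less compound is needed, a higher number that more compound is needed for the effect), so no number is known for it. Compound 2 `CCOC(=O)C(=O)Nc1nc2ccc(NC(=O)c3ccccc3)cc2s1` gives 9730 nM in this assay. Going by the values given here, compound 3 `CCOC(=O)C(=O)Nc1nc2ccc(NC(=O)c3cc(Br)c[nH]3)cc2s1` gives 27900 nM, the highest of the two numbers, and the single measured step, a 2.9-fold higher number from compound 2 to compound 3 (0.46 log units; beyond the scatter), is a modest rise beyond the scatter. Compound 4 `CCOC(=O)C(=O)Nc1nc2ccc(NC(=O)c3cc4ccccc4[nH]3)cc2s1` has not been measured. It differs from compound 3 in one place: 1H-indol-2-yl in place of 4-bromo-1H-pyrrol-2-yl on a carbonyl carbon. The bromine leaves, the five-membered aromatic ring with its hydrogen-bond donor stays, and a six-membered aromatic ring of carbon only joins it. Among the compounds with values here, the step from compound 2 to compound 3 is the only guide, and it showed that replacing a phenyl with the bromopyrrole raised the number modestly. Compound 2, with 9730 nM, carries a six-membered carbon ring, as the indole of compound 4 does. For compound 4 the expected step is therefore a modest drop, a 2.3-fold lower number from compound 3 to compound 4 (0.37 log units; beyond the scatter), though the two changes need not behave alike. The estimate for compound 4 is 12000 nM, with a range from 3500 nM to 40000 nM.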

Compound 4, half-maximal effective concentration: 6940 nM
Estimate against measurement, compound 4: 1.7-fold (0.24 log units) above; the range from low to high includes it.
By their numbers in this assay, from the lowest: compounds 4 and 2 (each within the scatter of the next); then compound 3. At a limit, above all of these: compound 1.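

In this assay, putting 1H-indol-2-yl in place of 4-bromo-1H-pyrrol-2-yl on this carbonyl carbon gives a 4.0-fold lower number from compound 3 to compound 4 (0.60 log units; beyond the scatter) and so reverses the rise seen on leaving phenyl. Set against phenyl, the same group gives a 1.4-fold lower number from compound 2 to compound 4 (0.15 log units; within the scatter) and makes no clear difference, so among compound 2, compound 3 and compound 4 only the 4-bromo-1H-pyrrol-2-yl group sets its compound apart. Nothing measured here gives a reason for these steps.

The compounds shown cannot separate the part played by the bromine from that of the ring carrying it, since they include neither an unsubstituted 1H-pyrrol-2-yl nor an indole bearing a bromine. Going by these compounds, how an amine or a carboxylic acid on the indole would behave also remains open.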